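From cyclopropylamino to benzylamino on the shared core

This account rests on a few compounds, and the source may have more. Where it says the series, first, only, none or still open, it means among the compounds named here.

In a functional assay on MGC-803 cells (Homo sapiens) for inhibition, read by sulforhodamine B assay (on this read-out lower numbers stand for stronger inhibition and higher numbers for weaker inhibition), compound 3 `O=C1C(NC2CC2)=CC(=O)c2c1nc1n2[C@H]2OC[C@@H](O)[C@H]2OC1` reports > 4000 nM as a limit and not as a number. Compound 1 `O=C1C(NC2CCCC2)=CC(=O)c2c1nc1n2[C@H]2OC[C@@H](O)[C@H]2OC1` reports > 16000 nM as a limit too. Compound 2 `O=C1C(N2CCC2)=CC(=O)c2c1nc1n2[C@H]2OC[C@@H](O)[C@H]2OC1` likewise reports > 16000 nM as a limit. Compound 3 thus stands without a number, and no order among the three can be read.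

Compound 4 `O=C1C(NCc2ccccc2)=CC(=O)c2c1nc1n2[C@H]2OC[C@@H](O)[C@H]2OC1` carries benzyl in place of cyclopropyl on an amine nitrogen, with the difference counted as benzyl in place of cyclopropyl on an amine nitrogen for the two structures. The closest measured change, also on an amine nitrogen, is a step that the two limits leave unreadable from compound 1 to compound 3 and offers no size to carry over. The changes involving azetidin-1-yl are a step that the two limits leave unreadable from compound 1 to compound 2 and a step that the two limits leave unreadable from compound 2 to compound 3 and offer none either.

The expectation thus rests on compound 3 and its limit of > 4000 nM alone, and no firm direction is expected in this assay for this change. The expected change is a step that the limit leaves unreadable from compound 3 to compound 4 with weak inhibition likely to persist. Compound 4 may well report only a limit too. Compound 4 is estimated at 10000 nM with an expected range from 3000 nM to 30000 nM in this read-out.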

Compound 4, half-maximal inhibitory concentration: 3490 nM
The estimate for compound 4 lay 2.9-fold (0.46 log units) above the measured number, within the range that was stated.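

Among the four compounds shown, compound 4 alone gives a number rather than a limit in this assay, while the steps among compound 1, compound 2 and compound 3 cannot be read. Benzyl in place of cyclopentyl on the amine nitrogen brings an at least 4.5-fold lower number from compound 1 to compound 4 (0.66 log units; beyond the scatter), and benzylamino in place of azetidin-1-yl brings an at least 4.5-fold lower number from compound 2 to compound 4 (0.66 log units; beyond the scatter), so this position can now be seen to respond to the change of group. Against cyclopropyl the result is less informative: the data give an at least 1.1-fold lower number from compound 3 to compound 4 (0.05 log units; that floor lies within the scatter), and no change beyond the scatter can be claimed for that pair.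

As far as these compounds go, how far compound 3 truly lies from compound 4 remains open. So does whether the number would hold with cyclohexylmethyl or 2-phenylethyl on the amine nitrogen.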